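The source may report more compounds than this note shows. Statements on the series, on what has been measured and on what is new or still open speak of the compounds shown alone.

Measured compounds:
Compound 1, `C#CCN(Cc1ccccc1)Cc1ccc2ccccc2c1`, gives 0% in an assay on HEK293 cells for binding affinity to Substance-K receptor (Rattus norvegicus), read by FRET, tested at 10 uM; on this read-out lower numbers stand for less inhibition and higher numbers for more inhibition at the one concentration tested (going by the name of the read-out).
Compound 2, `O=C(CN(Cc1ccccc1)Cc1ccc2ccccc2c1)OCCO`, gives 0% in this assay.

Compound 2 stands level with compound 1 at the digits shown, and the step of no change at the digits printed from compound 1 to compound 2 (within the scatter) lies within the scatter. Compound 3, `c1ccc(CN(Cc2ccc3ccccc3c2)c2cccnc2)cc1`, differs from compound 2 by pyridin-3-yl in place of ((2-hydroxyethoxy)carbonyl)methyl on an amine nitrogen. Within the data shown here, the one measured step, from compound 1 to compound 2, exchanged a group on a saturated chain carbon bound to an amine nitrogen rather than a group on the amine nitrogen itself, so it bears on the new change only loosely; it showed nothing beyond the scatter, and neither measured compound shows inhibition in this assay. Among the measured compounds shown here, no measured step exchanges a group on the amine nitrogen. The expected step is therefore none beyond the scatter, a number 5 percentage points higher from compound 2 to compound 3 (within the scatter). Compound 3 is estimated at 5%, with a range from 0% to 30%.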

Compound 3, a percentage reported as inhibition, at one concentration (the size of the read-out at that concentration, not a potency): 0%
For compound 3 the middle estimate is 5 percentage points above the measured one, and the stated range covers the measured number.
By their numbers in this assay, from the lowest: compounds 1, 2 and 3 (each within the scatter of the next).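

Compound 3 brings the first exchange read directly on the amine nitrogen, with an aromatic ring now bound there in place of a saturated chain. In this assay, pyridin-3-yl in place of ((2-hydroxyethoxy)carbonyl)methyl gives no change at the digits printed from compound 2 to compound 3 (within the scatter), and pyridin-3-yl in place of propargyl gives no change at the digits printed from compound 1 to compound 3 (within the scatter). The three groups on this nitrogen therefore cannot be ranked, since none of the compounds gives a reading that separates it from the others, and nothing available explains this result.

Still open, going by these compounds, is whether any other group on this nitrogen, such as a longer chain ending in an amine or a carboxylic acid, would give measurable inhibition. The compounds shown also leave open whether a change elsewhere on the shared core would do so.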